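Three Flat Aryl Swaps and a Chlorophenyl Newcomer

The source may hold more compounds than are shown below. What is called first, only, known or untested is meant among the compounds shown, and "the series" means these compounds.

Compound 3 `O=c1oc2ccccc2c2nc3c(ccc4cc[nH]c43)c(-c3cccnc3Cl)c12` carries a 2-chloropyridin-3-yl group on the shared core. In a functional assay on B16-F10 cells (Mus musculus) for cytotoxicity (on this read-out higher numbers stand for weaker inhibition and lower numbers for stronger inhibition), compound 3 gives 70700 nM. Two relatives share that core and differ only in the same aromatic group: compound 1 `O=c1oc2ccccc2c2nc3c(ccc4cc[nH]c43)c(-c3ccc(O)cc3)c12`, with a 4-hydroxyphenyl group, gives 70700 nM in this assay, and compound 2 `O=c1oc2ccccc2c2nc3c(ccc4cc[nH]c43)c(-c3ccc(Br)cc3)c12`, with a 4-bromophenyl group, gives 70700 nM. Compound 3 thus stands level with both: no change at the digits printed from compound 1 to compound 3 (within the scatter) and no change at the digits printed from compound 2 to compound 3 (within the scatter). The two earlier compounds are equally close to each other, no change at the digits printed from compound 1 to compound 2 (within the scatter).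

Compound 4 `O=c1oc2ccccc2c2nc3c(ccc4cc[nH]c43)c(-c3ccc(Cl)cc3)c12` has not yet been measured. The change from compound 3 is 4-chlorophenyl in place of 2-chloropyridin-3-yl on an aromatic carbon. Compound 2 also carries a halogen on a phenyl ring, so the flat step no change at the digits printed from compound 2 to compound 3 (within the scatter) bears most directly on this exchange; the two flat steps involving compound 1 point the same way. Three exchanges of this aromatic group, a hydroxy, a bromo and a chloropyridinyl variant, have left the read-out unmoved, so no step beyond the scatter is expected: no change at the digits printed from compound 3 to compound 4 (within the scatter). Compound 4 is therefore estimated at 70700 nM in this assay, with a range from 35000 nM to 141000 nM.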

Compound 4, half-maximal inhibitory concentration: 70700 nM
Estimate against measurement, compound 4: no gap at the digits printed; measured number inside the range.
By their numbers in this assay, from the lowest: compounds 1, 2, 3 and 4 (each within the scatter of the next).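

Removing the ring nitrogen, and with it the hydrogen-bond acceptor counted for 2-chloropyridin-3-yl, has no visible effect in this assay: the exchange for 4-chlorophenyl gives no change at the digits printed from compound 3 to compound 4 (within the scatter). Among the compounds shown here, the new compound also allows the first comparison of two halogens on a phenyl ring, where chloro in place of bromo gives no change at the digits printed from compound 2 to compound 4 (within the scatter) and chloro in place of hydroxy gives no change at the digits printed from compound 1 to compound 4 (within the scatter), so that this position has now taken four different six-membered aromatic groups without any step beyond the scatter. Nothing measured here explains why these compounds read alike, and the data offer no account of it.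

From the compounds shown here alone, all four groups are single six-membered aromatic rings attached at this carbon, so it remains open whether an amine, a carboxylic acid or a longer alkyl chain in their place would move the number in this assay at all. Going by these compounds, it also remains open whether changing another part of the shared core, such as the ring nitrogen-hydrogen, would shift the read-out.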